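Shortening the Acid Chain on Two Related Cores

A few compounds are considered here, and "the series" means these few. Any claim that something is new, unique, unknown or untested is made for them only; others in the source may bear on it.

Three compounds have been measured in an assay on HEK293 cells for inhibition of solute carrier family 22 member 12 (Homo sapiens), read by scintillation counting, with stated times of 30 min and 15 min; on this read-out lower numbers stand for stronger inhibition and higher numbers for weaker inhibition:

compound 1 `N#Cc1ccc(Nc2cnccc2SCCCC(=O)O)c2ccccc12`: 2780 nM
compound 2 `N#Cc1ccc(Nc2cnccc2SCCCCCCC(=O)O)c2ccccc12`: 5750 nM
compound 3 `N#Cc1ccc(Oc2cnccc2SCCCCCCC(=O)O)c2ccccc12`: 3780 nM

Compound 1 and compound 2 share one core and differ only in the acid-bearing chain: the change is carboxy in place of 3-carboxypropyl on a saturated chain carbon, three bonds along the chain from a sulfur, and it made a 2.1-fold lower number from compound 2 to compound 1 (0.32 log units; beyond the scatter). Compound 3 carries a different core; how that core differs from the core of compound 2 is not broken down here. Compound 4 `N#Cc1ccc(Oc2cnccc2SCCCC(=O)O)c2ccccc12` has not yet been measured. It relates to compound 3 by the same change, (carboxy in place of 3-carboxypropyl on a saturated chain carbon, three bonds along the chain from a sulfur), at the same place on the chain. Because the earlier step was a 2.1-fold lower number from compound 2 to compound 1 (0.32 log units; beyond the scatter), a step of similar size is expected here, namely a 2.1-fold lower number from compound 3 to compound 4 (0.32 log units; beyond the scatter). Compound 4 is therefore estimated at 1800 nM, with a likely range from 900 nM to 3600 nM.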

Compound 4, half-maximal inhibitory concentration: 1230 nM
Beside the measured number, compound 4's estimate is 1.5-fold (0.17 log units) above it; the range from low to high includes it.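

In this assay, putting carboxy in place of 3-carboxypropyl gives a 3.1-fold lower number from compound 3 to compound 4 (0.49 log units; beyond the scatter), a drop in the same direction as on the core of compound 2. The two steps do not differ in size by more than the usual variation between measurements: the same change on two cores in this assay, a 2.1-fold lower number (0.32 log units; beyond the scatter) from compound 2 to compound 1 and a 3.1-fold lower number (0.49 log units; beyond the scatter) from compound 3 to compound 4, 1.5-fold (0.17 log units) apart, within the scatter of two such steps. This shows that the change carried over between these two cores, but it does not show that it would hold on any other core, or why the shorter chain gives the lower number.

The compounds shown leave open how a chain of intermediate length or a still shorter chain would behave. They also leave open what an amide in place of the carboxylic acid would do.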